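Chain terminus in the dimethylaminopyridinol series

The source may hold more compounds than are shown below. What is called first, only, known or untested is meant among the compounds shown, and "the series" means these compounds.

Measured so far:
compound 1 `CCCCCCCCCCCCCCCCc1c(C)c(N(C)C)nc(C)c1O` 56%
compound 2 `CCCCCCCCCCc1c(C)c(N(C)C)nc(C)c1O` 87%
compound 3 `Cc1c(N(C)C)nc(CCCCCCCCCCO)c(O)c1C` 36%

In a functional assay on cells (Lymphocyte, Homo sapiens), read by trypan blue exclusion, with a stated time of 16 h, tested at 0.5 uM (on this read-out higher numbers stand for a stronger effect at the one concentration tested and lower numbers for a weaker effect), compound 3 stands lowest of the three; compound 1 sits above it and compound 2 is furthest above it. Compound 4 `CCCCCCCCCCCCCCCCCCCc1nc(N(C)C)c(C)c(C)c1O` is not yet measured; it differs from compound 3 by nonyl in place of hydroxy on a saturated chain carbon, ten or more bonds along the chain from an aromatic carbon. Within the data shown here, the only one-place step available, a number 31 percentage points higher from compound 1 to compound 2 (beyond the scatter), runs the other way along the chain: shortening raised the number, and compound 4 carries a longer all-carbon chain than compound 1. Compound 2 and compound 3 share chain length but differ in more than one place, so their values are noted without a step. For compound 4 a modest rise toward compound 1 is expected, a number 9 percentage points higher from compound 3 to compound 4 (within the scatter). Compound 4 is estimated at 45%, between 20% and 70%.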

Compound 4, a percentage reported as activity, at one concentration (the size of the read-out at that concentration, not a potency): 7%
Compound 4: middle estimate off by 38 percentage points, on the high side, outside the stated range (below it).
By their numbers in this assay, from the lowest: compound 4; then compound 3; then compound 1; then compound 2.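

In this assay the far end of the chain now has a measured effect of its own: nonyl in place of hydroxy, on a saturated chain carbon, gives a number 29 percentage points lower from compound 3 to compound 4 (beyond the scatter) in this series. Together with a number 31 percentage points higher from compound 1 to compound 2 (beyond the scatter), both steps tie more all-carbon chain to a lower number, and neither goes against this, though only these two steps bear on it. No measured evidence accounts for this result.

On these data alone, whether the drop tracks the loss of hydroxy or the added nonyl stays open. An amine or a carboxylic acid at the chain end could help separate the two.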